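Working notes: compound 3 as the methyl counterpart of compound 2

The compounds below may be only part of what the source reports. "The series", "measured", "known", "first", "only" and "open" are said of these compounds alone.

Measured compounds:
- compound 1, `Cc1nc(Nc2ccccc2)sc1C(=O)/C=C/c1ccc(Cl)cc1`: > 25000 nM
- compound 2, `Cc1nc(Nc2cccc(Cl)c2)sc1C(=O)/C=C/c1ccc(Cl)cc1`: > 25000 nM

Both measured values are limits of the assay, not numbers. In a functional assay on Bel-7402 cells (Homo sapiens) for cytotoxicity, read by MTT assay (a lower number here means a stronger inhibitor, a higher number a weaker inhibitor), compound 1 gives > 25000 nM, a limit. In this assay compound 2 gives > 25000 nM, likewise a limit. Within the data shown here, the single step between them, a step that the two limits leave unreadable from compound 1 to compound 2, therefore cannot be read in either direction; the position of compound 2 is known only as sitting at the limit of > 25000 nM in this assay, at which 2 of the 2 values shown sit.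

Compound 3, `Cc1cccc(Nc2nc(C)c(C(=O)/C=C/c3ccc(Cl)cc3)s2)c1`, differs from compound 2 by methyl in place of chloro on an aromatic carbon. Among the measured compounds shown here, no measured step touches a methyl group, and the only step in hand, from compound 1 to compound 2, is unreadable, so there is no quantitative anchor for the size or direction of this change. For the measured compounds named here, both measured analogues share the limit, which is the only evidence on where this part of the series lies.

Compound 3 is expected to remain at or near that limit, with the step that the limit leaves unreadable from compound 2 to compound 3 estimated as nothing beyond the scatter. The estimate for compound 3 in this assay is 30000 nM, with a range of 8000 nM to 120000 nM, and most likely reported again only as a limit.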

Compound 3, half-maximal inhibitory concentration: > 25000 nM
Compound 3: only a limit was reported; the forecaster's own chance of this, stated with the estimate: 80%; the middle value lies beyond the limit too.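

In this assay compound 3 gives > 25000 nM, a limit and not a number. No step among compound 1, compound 2 and compound 3 can be read, as all three sit at one limit: the limit of > 25000 nM in this assay, at which 3 of the 3 values shown sit.

The compounds shown leave open whether hydrogen, chloro or methyl on that aromatic carbon makes any difference in this assay.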